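A few compounds are considered here, and "the series" means these few. Any claim that something is new, unique, unknown or untested is made for them only; others in the source may bear on it.

Measured so far:
compound 1 `O=C(CCN1C(=O)CSc2ccccc21)N1CCN(c2ccc(C(F)(F)F)cc2)CC1`: 46400 nM
compound 2 `COc1ccccc1N1CCN(C(=O)CCN2C(=O)CSc3ccccc32)CC1`: > 100000 nM
compound 3 `COc1ccccc1N1CCN(CCCNC(=O)CCN2C(=O)CSc3ccccc32)CC1`: > 100000 nM

All three were tested in a functional assay on IMR-32 cells (Homo sapiens) for inhibition, read by sulforhodamine B assay, with a stated time of 48 h; on this read-out higher numbers stand for weaker inhibition of growth and lower numbers for stronger inhibition of growth. Compound 1 gives 46400 nM. For compound 2 the result is only a limit of the assay, > 100000 nM. For compound 3 the result is likewise only a limit, > 100000 nM. Compound 1 and compound 2 differ in one place: 4-(trifluoromethyl)phenyl in place of 2-methoxyphenyl on an amine nitrogen in a ring. This change gave an at least 2.1-fold lower number from compound 2 to compound 1 (0.33 log units; beyond the scatter), a size bounded by the limit of > 100000 nM in this assay, at which 2 of the 3 values shown sit. How the cores of compound 2 and compound 3 differ is not broken down here. Compound 4 `O=C(CCN1C(=O)CSc2ccccc21)NCCCN1CCN(c2ccc(C(F)(F)F)cc2)CC1` has not yet been measured; it differs from compound 3 by 4-(trifluoromethyl)phenyl in place of 2-methoxyphenyl on an amine nitrogen in a ring, the same change. In this assay compound 4 is expected to show an at least 1.6-fold lower number from compound 3 to compound 4 (0.22 log units; that floor lies within the scatter), an expectation resting on an at least 2.1-fold lower number from compound 2 to compound 1 (0.33 log units; beyond the scatter). The estimate for compound 4 is 60000 nM, expected to lie between 20000 nM and 150000 nM.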

Compound 4, concentration for 50% growth inhibition: 1400 nM
Compound 4: middle estimate off by 43-fold (1.63 log units), on the high side; measured number outside the range, below it.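

In this assay, putting 4-(trifluoromethyl)phenyl in place of 2-methoxyphenyl gave an at least 71-fold lower number from compound 3 to compound 4 (1.85 log units; beyond the scatter), so the direction of the change carried over to a second core. Its size cannot be compared with that of the earlier step: the same change on two cores in this assay, an at least 2.1-fold lower number (0.33 log units; beyond the scatter) from compound 2 to compound 1 and an at least 71-fold lower number (1.85 log units; beyond the scatter) from compound 3 to compound 4; the limit leaves it open whether they differ. Each step starts from a limit of the assay rather than a number, so neither step has a known true size: the limit of > 100000 nM in this assay, at which 2 of the 4 values shown sit.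

The compounds shown leave open whether other groups at that place, such as plain phenyl or 4-chlorophenyl, would follow the same direction, and whether 4-methoxyphenyl would differ from 2-methoxyphenyl. They also leave open what a longer chain in the core of compound 4 would do.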